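Toward Compound 4: Expected Maximal Response at the Atrium

The source may report more compounds than this note shows. Statements on the series, on what has been measured and on what is new or still open speak of the compounds shown alone.

Compound 1 `N=C(NCCCc1c[nH]cn1)NCCCC(c1ccc(F)cc1)c1ccccn1`: 0.9
Compound 2 `N=C(NCCCc1c[nH]cn1)NCCC(c1ccccc1)c1ccccn1`: 1
Compound 3 `COc1ccc(C(CC/N=C(\N)NCCCc2c[nH]cn2)c2ccccn2)cc1`: 1

All three were tested in a functional assay on cardiac atrium for agonist activity at histamine H2 receptor (Cavia porcellus); a lower number here means a smaller maximal response, a higher number a larger maximal response. Compound 2 stands level with compound 3 at the digits given, the two together the highest of the three numbers; compound 1 lies lower, but within the scatter. Compound 4 `N=C(NCCCc1c[nH]cn1)NCCC(c1cc(F)cc(F)c1)c1ccccn1` has not yet been measured. It differs from compound 2 by 3,5-difluorophenyl in place of phenyl on a saturated chain carbon bound to an aromatic carbon and a saturated chain carbon. Among the measured compounds shown here, no step between measured compounds isolates such a change. A step no larger than the scatter is expected, with no direction, because compound 1 gives 0.9 while carrying a fluorine-bearing ring; the expected step is a number 0.050 lower from compound 2 to compound 4 (within the scatter). For compound 4 the estimate is 0.95, within 0.8 to 1.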

Compound 4, intrinsic activity: the largest response reached, as a fraction of the reference agonist's: 1
Compound 4: the middle estimate sits 0.050 below what was measured; the measured number falls inside the stated range.
By their numbers in this assay, from the lowest: compounds 1, 2, 3 and 4 (each within the scatter of the next).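

In this assay the exchange of phenyl for 3,5-difluorophenyl gives no change at the digits printed from compound 2 to compound 4 (within the scatter) and is the first step shown that isolates a change at this position. It shows that this saturated chain carbon can carry the two-fluorine ring while the maximal response stays within the scatter of that of the unsubstituted phenyl compound. Nothing at hand accounts for this result. The compounds shown leave open whether 3,5-dichlorophenyl or cyclohexyl in the same place would hold the maximal response.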